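Replacing pyridin-2-yl with 3-methoxyphenyl on the hydrazone carbon

This account rests on a few compounds, and the source may have more. Where it says the series, first, only, none or still open, it means among the compounds named here.

Compound 1, `Cc1c(C(=O)N/N=C\c2ccccc2O)oc2cccc(O)c12`: 8350 nM
Compound 2, `Cc1c(C(=O)N/N=C\c2ccccn2)oc2cccc(O)c12`: >= 40000 nM

The two measured compounds share one core and differ only in the aryl group on a carbon with a double bond to nitrogen. In a functional assay on PC-3 cells (Homo sapiens) for inhibition (on this read-out lower numbers stand for stronger inhibition and higher numbers for weaker inhibition), compound 1 gives 8350 nM. For compound 2 the assay returns only a limit, >= 40000 nM (the limit of >= 40000 nM in this assay, at which 1 of the 2 values shown sits). Going by the values given here, the single measured step, an at least 4.7-fold higher number from compound 1 to compound 2 (0.68 log units; beyond the scatter), has no fixed size, only a lower bound. Compound 3, `COc1cccc(/C=N\NC(=O)c2oc3cccc(O)c3c2C)c1`, is not yet measured; it differs from compound 2 in that (3-methoxyphenyl in place of pyridin-2-yl on a carbon with a double bond to nitrogen). This returns to a carbon-only ring, as in compound 1, though with a different substituent. Among the compounds with values here, that one step is the only guide, and it points to a lower number for compound 3 than the limit of compound 2. Compound 3 is expected to show an at least 2.6-fold lower number from compound 2 to compound 3 (0.42 log units; beyond the scatter), with an estimate of 15000 nM in the range 5000 nM to 45000 nM.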

Compound 3, half-maximal inhibitory concentration: >= 40000 nM
Compound 3 was reported as a limit; the forecaster's own chance of this, stated with the estimate: 30%; at least 2.6-fold (0.42 log units) between middle value and limit.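

In this assay compound 3 gives >= 40000 nM, which is a limit and not a number. A carbon-only ring on the carbon with a double bond to nitrogen is thus not enough to give a readable value here, and putting 3-methoxyphenyl in place of 2-hydroxyphenyl gives an at least 4.7-fold higher number from compound 1 to compound 3 (0.68 log units; beyond the scatter). The change from pyridin-2-yl to 3-methoxyphenyl cannot be read, as both values are limits: the limit of >= 40000 nM in this assay, at which 2 of the 3 values shown sit.

On these data alone, how far the true values of compound 2 and compound 3 lie from that limit stays open. So does whether the readable value of compound 1 depends on the hydroxy group of its 2-hydroxyphenyl, a question that a plain phenyl group at this place would bear on.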